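Cyclohexyl for isopentyl at the ring nitrogen

The compounds below may be only part of what the source reports. "The series", "measured", "known", "first", "only" and "open" are said of these compounds alone.

Among the measured compounds shown here, compound 1 `CC(C)CCn1cnc2c(Nc3ccc(Cl)cc3)nc(N[C@H]3CC[C@H](N)CC3)nc21` gives 2700 nM in a functional assay on MCF7 cells (Homo sapiens) for inhibition, read by fluorescence, with a stated time of 72 h (on this read-out higher numbers stand for weaker inhibition of growth and lower numbers for stronger inhibition of growth), one of only two numbers so far, the other within the scatter of it. Compound 2 `CC(C)CCn1cnc2c(Nc3ccccc3)nc(N[C@H]3CC[C@H](N)CC3)nc21`, which gives 5400 nM, sits at a 2.0-fold higher number from compound 1 to compound 2 (0.30 log units; within the scatter). Compound 3 `N[C@H]1CC[C@H](Nc2nc(Nc3ccc(Cl)cc3)c3ncn(C4CCCCC4)c3n2)CC1` differs from compound 1 by cyclohexyl in place of isopentyl on an aromatic nitrogen. For the measured compounds named here, no measured step touches the aromatic nitrogen; the one step known, hydrogen in place of chloro, concerns another place and lay within the scatter, so it gives no lead. For compound 3 a step of a 1.1-fold lower number from compound 1 to compound 3 (0.03 log units; within the scatter) is expected, nothing beyond the scatter. Compound 3 is estimated at 2500 nM, with a range from 800 nM to 8000 nM.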

Compound 3, concentration for 50% growth inhibition: 2300 nM
The estimate for compound 3 lay 1.1-fold (0.04 log units) above the measured number, within the range that was stated.
By their numbers in this assay, from the lowest: compounds 3, 1 and 2 (each within the scatter of the next, the first and the last beyond it).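

Among the compounds shown here, the first step at the ring nitrogen swaps an open chain for a ring without moving the number: in this assay cyclohexyl in place of isopentyl gives a 1.2-fold lower number from compound 1 to compound 3 (0.07 log units; within the scatter) and so stays within the scatter. The position therefore accepts both isopentyl and cyclohexyl with the chloro group held constant. No available evidence bears on this result.

On these data alone, whether methyl, or a chain carrying an amine or a carboxylic acid, at the ring nitrogen would move the number beyond the scatter remains open. So does the effect of cyclohexyl in a compound with hydrogen in place of chloro.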